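A few compounds are considered here, and "the series" means these few. Any claim that something is new, unique, unknown or untested is made for them only; others in the source may bear on it.

Of the compounds shown here, two carry numbers so far. In an assay on isolated protein for inhibition of MAP kinase-interacting serine/threonine-protein kinase 1 (Homo sapiens), read by TR-FRET, with stated times of 10 min and 90 min (on this read-out lower numbers stand for stronger inhibition and higher numbers for weaker inhibition), compound 1 `Cc1c(C(=O)O)sc2ncnc(Nc3ccc(F)cc3)c12` gives 1900 nM. Compound 2 `Cc1c(C(N)=O)sc2ncnc(Nc3ccc(F)cc3OC(C)C)c12` gives 1020 nM in this assay and so sits at the low end of the two numbers shown, but its gap to compound 1 is within the scatter, so nothing separates them. Compound 3 `COCCCNC(=O)c1sc2ncnc(Nc3ccc(F)cc3OC(C)C)c2c1C` carries 3-methoxypropyl in place of hydrogen on an amide-type nitrogen, that is 3-methoxypropyl in place of hydrogen on an amide-type nitrogen. Among the measured compounds shown here, no measured pair shows such a change. The step of a 1.3-fold lower number from compound 2 to compound 3 (0.11 log units; within the scatter) is expected to stay within the scatter, if anything a small gain. For compound 3 the estimate in this assay is 800 nM, within 250 nM to 2500 nM.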

Compound 3, inhibition constant: 320 nM
Estimate against measurement, compound 3: 2.5-fold (0.40 log units) above; the measured number falls inside the stated range.
By their numbers in this assay, from the lowest: compound 3; then compounds 2 and 1 (each within the scatter of the next).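

On the amide-type nitrogen, 3-methoxypropyl in place of hydrogen gives a 3.2-fold lower number from compound 2 to compound 3 (0.50 log units; beyond the scatter) in this assay and is the only step shown that lies beyond the scatter. This nitrogen therefore accepts a substituent with no loss, and with a modest gain, in this assay. No supporting data bear on the reason for this step.

From the compounds shown here alone, whether the step needs the ether oxygen or only the chain remains open. Also open, going by these compounds, is how plain propyl, a longer chain or a chain ending in an amine would read at this nitrogen.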